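Chain Length and Dopamine Beta-Hydroxylase Inhibition

The source may hold more compounds than are shown below. What is called first, only, known or untested is meant among the compounds shown, and "the series" means these compounds.

In an assay on isolated protein (adrenal medulla) for inhibition of Dopamine beta-hydroxylase (Bos taurus) (on this read-out higher numbers stand for weaker inhibition and lower numbers for stronger inhibition), three compounds share one core and differ only in the chain attached to an aromatic nitrogen. Compound 1, `CCn1cnc(N)c2ncnc1-2`, carries an ethyl chain; in this assay compound 1 gives only a limit of the assay, > 200 ug/mL. Compound 2, `CCCCn1cnc(N)c2ncnc1-2`, carries a butyl chain, and in this assay compound 2 gives 20 ug/mL. Compound 3, `CCCCCCn1cnc(N)c2ncnc1-2`, carries a hexyl chain, and in this assay compound 3 gives 1 ug/mL, the lowest of the two numbers recorded. The measured steps all run the same way: an at least 10-fold lower number from compound 1 to compound 2 (1.00 log units; beyond the scatter), an at least 200-fold lower number from compound 1 to compound 3 (2.30 log units; beyond the scatter) and a 20-fold lower number from compound 2 to compound 3 (1.30 log units; beyond the scatter), each beyond the scatter, and each time a longer chain goes with a lower number.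

Compound 4, `CC(C)CCn1cnc(N)c2ncnc1-2`, differs from compound 3 by isopropyl in place of butyl on a saturated chain carbon, two bonds along the chain from an aromatic nitrogen. The chain is thus shortened and branched rather than lengthened. Going by the values given here, the steps that bear on this change are those between compounds 1, 2 and 3, where shortening the chain raised the number each time, so a modest rise in this assay is expected here, though a branched chain has not yet been measured and may not follow the straight chains exactly. The step from compound 3 to compound 4 is expected to be a 4.0-fold higher number from compound 3 to compound 4 (0.60 log units; beyond the scatter). Compound 4 is therefore estimated at 4 ug/mL, within a range from 1 ug/mL to 15 ug/mL.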

Compound 4, half-maximal inhibitory concentration: 200 ug/mL
For compound 4 the middle estimate is 50-fold (1.70 log units) below the measured one, and the stated range ends below it.
By their numbers in this assay, from the lowest: compound 3; then compound 2; then compound 4.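

Replacing butyl with isopropyl on a saturated chain carbon, two bonds along the chain from an aromatic nitrogen, gives a 200-fold higher number from compound 3 to compound 4 (2.30 log units; beyond the scatter) in this assay, a large step. The comparison with the shorter straight chain is more telling: placing methyl in place of hydrogen on a saturated chain carbon bound to two saturated chain carbons adds a carbon yet gives a 10-fold higher number from compound 2 to compound 4 (1.00 log units; beyond the scatter), against the lower numbers that went with longer straight chains in compounds 1, 2 and 3, so the carbon count alone does not set the number in this small set, and the shape of the chain counts too. Compound 1 gives only a limit of the assay. The step that rests on this limit reads a number no higher from compound 1 to compound 4 (the limit leaves the size open), and its size cannot be read: the limit of > 200 ug/mL in this assay, at which 1 of the 4 values shown sits.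

With a single branched chain shown, it remains open whether a branch placed elsewhere on the chain, such as one nearer the aromatic nitrogen, would cost as much. On these data alone, it is also open how far the trend with length runs in a longer straight chain such as octyl, and what an amine or a carboxylic acid at the end of the hexyl chain would do.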